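The source may hold more compounds than are shown below. What is called first, only, known or untested is meant among the compounds shown, and "the series" means these compounds.

Measured in an in vivo ADME assay on the whole organism (Canis lupus familiaris) for pharmacokinetics; on this read-out lower numbers stand for lower oral bioavailability and higher numbers for higher oral bioavailability:
- compound 1 `O=C(O)CC(NC(=O)CCCCc1ccc2c(n1)NCCC2)c1cncnc1`: 10%
- compound 2 `O=C(O)C[C@H](CCCCCCc1ccc2c(n1)NCCC2)c1cncnc1`: 66%
- compound 3 `O=C(O)C[C@H](CCCCCCc1ccc2c(n1)NCCC2)c1cnc2ccccc2c1`: 65%

Compound 3 at 65% lies within the scatter of compound 2 at 66%. Compound 1 gives 10%. The gap between compound 1 and compound 3 lies beyond the scatter. Next is compound 4 `COc1ccc([C@@H](CCCCCCc2ccc3c(n2)NCCC3)CC(=O)O)cn1`, with 6-methoxypyridin-3-yl in place of quinolin-3-yl on a saturated chain carbon bound to two saturated chain carbons. For the measured compounds named here, one measured step bears on this, a change of group at the same place: a number 1 percentage points lower from compound 2 to compound 3 (within the scatter). Going by the values given here, it stayed within the scatter, and no measured step covers the entering group. The expected change in this assay is therefore none beyond the scatter, an estimated a number 5 percentage points lower from compound 3 to compound 4 (within the scatter). For compound 4 the estimate is 60%, with an expected range of 40% to 78%.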

Compound 4, oral bioavailability: 49%
Compound 4: middle estimate off by 11 percentage points, on the high side; low and high end bracket the measured number.
By their numbers in this assay, from the lowest: compound 1; then compound 4; then compounds 3 and 2 (each within the scatter of the next).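

In this assay, the group on a saturated chain carbon bound to two saturated chain carbons can shift the read-out: 6-methoxypyridin-3-yl in place of quinolin-3-yl gives a number 16 percentage points lower from compound 3 to compound 4 (beyond the scatter) and 6-methoxypyridin-3-yl in place of pyrimidin-5-yl gives a number 17 percentage points lower from compound 2 to compound 4 (beyond the scatter) at the same place. For the compounds shown here, the one earlier change here, quinolin-3-yl in place of pyrimidin-5-yl, stayed within the scatter and gave no sign of such a step. Nothing available explains this step. As far as these compounds go, whether the step follows the methoxy group or the ring bearing it remains open. Unsubstituted pyridin-3-yl at this place would separate the two.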